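A few compounds are considered here, and "the series" means these few. Any claim that something is new, unique, unknown or untested is made for them only; others in the source may bear on it.

Measured compounds:
Compound 1 `COC(=O)c1nc(C2CCCCC2)n(-c2ccc(F)cc2)n1`; in a functional assay on Jurkat cells (Homo sapiens) for inhibition, read by MTT assay, with a stated time of 72 h (on this read-out lower numbers stand for stronger inhibition of growth and higher numbers for weaker inhibition of growth), compound 1 gives > 100000 nM, a limit of the assay.
Compound 2 `COC(=O)c1nc(C2CCCCC2)n(-c2ccc(C(F)(F)F)cc2)n1`; in this assay compound 2 gives > 100000 nM, a limit of the assay.
Compound 3 `CCOC(=O)c1nc(-c2ccc[nH]2)n(-c2ccc(C(F)(F)F)cc2)n1`; in this assay compound 3 gives > 100000 nM, a limit of the assay.

Compounds 1 and 2 share one core. Compound 3 carries another core; the difference between the two cores is not broken down here. Within the first core the change fluoro in place of trifluoromethyl on an aromatic carbon is made, and the step that the two limits leave unreadable from compound 2 to compound 1 cannot be read because of the limit of > 100000 nM in this assay, at which 3 of the 3 values shown sit.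

Compound 4 `CCOC(=O)c1nc(-c2ccc[nH]2)n(-c2ccc(F)cc2)n1` differs from compound 3 by fluoro in place of trifluoromethyl on an aromatic carbon. Among the measured compounds shown here, the place lines of the two changes agree word for word, so this is the same change as the one from compound 2 to compound 1.

For the measured compounds named here, the only measured example of this change gives no readable size, and the three values shown are all limits. Compound 4 is therefore expected to stay at the limit as well, so that the step that the limit leaves unreadable from compound 3 to compound 4 is an estimated step of no readable size. The estimate for compound 4 is 150000 nM, with 50000 nM to 500000 nM as its expected range.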

Compound 4, concentration for 50% growth inhibition: > 100000 nM
Compound 4: a limit, no number (the forecaster's own chance of this, stated with the estimate: 85%); the middle value is on the limit's open side.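

The step from compound 3 to compound 4 in this assay cannot be read, because both values are limits of the assay: the limit of > 100000 nM in this assay, at which 4 of the 4 values shown sit.

The compounds shown leave open whether fluoro in place of trifluoromethyl changes growth inhibition at all, and which structure in this series, if any, would give a value inside the assay's range.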